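The source may report more compounds than this note shows. Statements on the series, on what has been measured and on what is new or still open speak of the compounds shown alone.

Measured compounds:
Compound 1 `Cc1ccccc1-c1nnc(N(N)C(C)C)s1`: in a functional assay on the whole organism with Mus musculus as the target, in the maximal electroshock model, with a stated time of 1 h (on this read-out higher numbers stand for an effect only at larger amounts of compound and lower numbers for an effect already at smaller amounts), compound 1 gives 54 mg/kg.
Compound 2 `CC(C)N(N)c1nnc(-c2ccccc2Cl)s1`: in this assay compound 2 gives 54 mg/kg.
Compound 3 `CNN(C)c1nnc(-c2ccccc2C)s1`: in this assay compound 3 gives 10 mg/kg.

Compound 1 and compound 2 share a core and differ only in one place: chloro in place of methyl on an aromatic carbon. That change made the step of no change at the digits printed from compound 1 to compound 2 (within the scatter). The core of compound 3 differs from that of compound 1 by methyl(methylamino)amino in place of amino(isopropyl)amino on an aromatic carbon, and this change made the step of a 5.4-fold lower number from compound 1 to compound 3 (0.73 log units; beyond the scatter), so compound 3 stands lowest of the three measured compounds.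

Compound 4 `CNN(C)c1nnc(-c2ccccc2Cl)s1` has not been measured. It differs from compound 3 by chloro in place of methyl on an aromatic carbon. For the measured compounds named here, this is the same kind of change as the one from compound 1 to compound 2, though the surroundings are not described identically: in compound 1 the place is ortho to a large group, while in compound 3 it is ortho to a group of 9 heavy atoms. Because the earlier step of no change at the digits printed from compound 1 to compound 2 (within the scatter) stayed within the scatter, the step from compound 3 to compound 4 is expected to be a 1.1-fold higher number from compound 3 to compound 4 (0.04 log units; within the scatter). Compound 4 is therefore estimated at 11 mg/kg in this assay, with an expected range from 5 mg/kg to 24 mg/kg.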

Compound 4, dose for half-maximal effect: 43 mg/kg
The estimate for compound 4 lay 3.9-fold (0.59 log units) below the measured number, outside the stated range (above it).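

In this assay, chloro in place of methyl on an aromatic carbon gave a 4.3-fold higher number from compound 3 to compound 4 (0.63 log units; beyond the scatter), so this swap cannot be carried unchanged from the core of compound 1 to the core of compound 3: the same change on two cores in this assay, no change at the digits printed (within the scatter) from compound 1 to compound 2 and a 4.3-fold higher number (0.63 log units; beyond the scatter) from compound 3 to compound 4, 4.3-fold (0.63 log units) apart, beyond the scatter of two such steps

The other change, methyl(methylamino)amino in place of amino(isopropyl)amino, likewise depends on its surroundings, since with chloro on the ring it gave only a 1.3-fold lower number from compound 2 to compound 4 (0.10 log units; within the scatter): the same change on two cores in this assay, a 5.4-fold lower number (0.73 log units; beyond the scatter) from compound 1 to compound 3 and a 1.3-fold lower number (0.10 log units; within the scatter) from compound 2 to compound 4, 4.3-fold (0.63 log units) apart, beyond the scatter of two such steps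

These four compounds show that the two changes do not simply add up, so the effect of one cannot be read without knowing the other, but they do not show why this happens or whether it would hold for any other pair of groups.

As far as these compounds go, a fluoro or a methoxy group at the same place on the aromatic ring remains open, as does the question of whether it would follow the methyl or the chloro compounds. Also open, from the compounds shown here alone, is what an ethyl group in place of the isopropyl group would do on either ring.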